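The source may report more compounds than this note shows. Statements on the series, on what has been measured and on what is new or still open speak of the compounds shown alone.

Measured so far in an assay on HEK293 cells for agonist activity at prostaglandin E2 receptor EP2 subtype (Homo sapiens), read by a beta-galactosidase reporter and beta-arrestin recruitment, with a stated time of 90 min; a lower number here means that less compound is needed, a higher number that more compound is needed for the effect:

compound 1 `O=C(O)c1csc([C@H]2CC[C@@H]3[C@@H](COc4ccc(C(F)(F)F)cc4)[C@H](O)C[C@@H]3O2)n1`: > 10000 nM.
compound 2 `O=C(O)c1csc([C@H]2CC[C@@H]3[C@@H](COc4cccc(F)c4)[C@H](O)C[C@@H]3O2)n1`: > 10000 nM.
compound 3 `O=C(O)c1csc([C@H]2CC[C@@H]3[C@@H](COc4ccccc4C(F)(F)F)[C@H](O)C[C@@H]3O2)n1`: 11 nM.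

For compound 1 the value > 10000 nM is a limit of the assay, not a number. For compound 2 the value > 10000 nM is likewise a limit. Compound 3 gives 11 nM in this assay. Compound 1 therefore stands at the limit of > 10000 nM in this assay, at which 2 of the 3 values shown sit.

Compound 4 `O=C(O)c1csc([C@H]2CC[C@@H]3[C@@H](COc4ccccc4Cl)[C@H](O)C[C@@H]3O2)n1` differs from compound 1 by 2-chlorophenyl in place of 4-(trifluoromethyl)phenyl on an oxygen on a saturated carbon. For the measured compounds named here, the steps that bear on this change are an at least 900-fold lower number from compound 1 to compound 3 (2.95 log units; beyond the scatter) and an at least 900-fold lower number from compound 2 to compound 3 (2.95 log units; beyond the scatter), both moving to a 2-(trifluoromethyl)phenyl. Going by the values given here, no measured compound carries a 2-chlorophenyl, so compound 4 is expected to show a large step, an at least 250-fold lower number from compound 1 to compound 4 (2.39 log units; beyond the scatter), though its size remains uncertain. Compound 4 is estimated at 40 nM, within 8 nM to 400 nM.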

Compound 4, half-maximal effective concentration: 203 nM
Beside the measured number, compound 4's estimate is 5.1-fold (0.71 log units) below it, and the stated range covers the measured number.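

Activity at this place does not depend on 2-(trifluoromethyl)phenyl alone, since 2-chlorophenyl also gives a measurable value, with an at least 49-fold lower number from compound 1 to compound 4 (1.69 log units; beyond the scatter) and an at least 49-fold lower number from compound 2 to compound 4 (1.69 log units; beyond the scatter). Those two steps start from a limit of the assay, not from a number: the limit of > 10000 nM in this assay, at which 2 of the 4 values shown sit. The group still matters, as chloro in place of trifluoromethyl gives an 18-fold higher number from compound 3 to compound 4 (1.27 log units; beyond the scatter).

Going by these compounds, what remains open is how a 2-methylphenyl or a 2-methoxyphenyl would compare with these two groups. On these data alone, it is also open whether an unsubstituted phenyl would give any measurable value at all.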